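This account rests on a few compounds, and the source may have more. Where it says the series, first, only, none or still open, it means among the compounds named here.

Measured in a functional assay on M21 cells (Homo sapiens) for antiproliferative activity, read by sulforhodamine B assay, with a stated time of 48 h; on this read-out higher numbers stand for weaker inhibition and lower numbers for stronger inhibition:
compound 1 `O=C1NCCN1c1ccc(S(=O)(=O)Nc2ccc(OC(F)F)cc2)cc1` gives 410 nM
compound 2 `O=C1NCCN1c1ccc(S(=O)(=O)Nc2ccc(F)c(F)c2)cc1` gives 220 nM
compound 3 `CC(C)Cc1ccc(NS(=O)(=O)c2ccc(N3CCNC3=O)cc2)cc1` gives > 1000 nM

Compound 3 stands apart from the other two: its value is a limit of this assay rather than a number, as the limit of > 1000 nM in this assay, at which 1 of the 3 values shown sits, shows. Among the measured compounds shown here, the one measured step that leads to compound 3 is an at least 2.4-fold higher number from compound 1 to compound 3 (0.38 log units; beyond the scatter), so introducing isobutyl is the change associated with the loss of a measurable number. Compound 4 `O=C1NCCN1c1ccc(S(=O)(=O)Nc2ccc(Br)cc2)cc1` differs from compound 3 by bromo in place of isobutyl on an aromatic carbon. For the measured compounds named here, only that step bears on the new change, and it runs the other way: isobutyl leaves again. Compounds 1 and 2, which lack the isobutyl group, both give numbers within the measured range, so compound 4 is expected to return from the limit to a measurable value, and the step from compound 3 to compound 4 in this assay is estimated as an at least 2.5-fold lower number from compound 3 to compound 4 (0.39 log units; beyond the scatter). The expected value of compound 4 in this assay is 400 nM, with a range from 150 nM to 1200 nM.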

Compound 4, half-maximal inhibitory concentration: 130 nM
Compound 4: the middle estimate sits 3.1-fold (0.49 log units) above what was measured; measured number below the stated range.
By their numbers in this assay, from the lowest: compounds 4, 2 and 1 (each within the scatter of the next, the first and the last beyond it). At a limit, above all of these: compound 3.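

At this aromatic carbon, para to a large group, bromo in compound 4 gives a measurable number in this assay, with an at least 7.6-fold lower number from compound 3 to compound 4 (0.88 log units; beyond the scatter), so a group of this place can leave the limit with a single heavy atom. Bromo also separates from difluoromethoxy beyond the scatter, with a 3.2-fold lower number from compound 1 to compound 4 (0.50 log units; beyond the scatter), while the exchange for 3,4-difluorophenyl stays within the scatter, with a 1.7-fold lower number from compound 2 to compound 4 (0.23 log units; within the scatter). Compound 3 remains a limit and not a number, which makes its step a bound only: the limit of > 1000 nM in this assay, at which 1 of the 4 values shown sits.

As far as these compounds go, whether a shorter chain such as ethyl would stay in the measurable range as bromo does, or fall to the limit as isobutyl does, stays open. So does the outcome of an amine or a carboxylic acid at this carbon.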